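Cyclopropylmethyl in place of cyclopropyl at the assay limit

The source may report more compounds than this note shows. Statements on the series, on what has been measured and on what is new or still open speak of the compounds shown alone.

In an ADME assay on MT4 cells (Homo sapiens) for cytotoxicity, read by MTT assay, with a stated time of 5 days (on this read-out higher numbers stand for lower toxicity in this test and lower numbers for higher toxicity in this test), compound 1 (`COc1cc2cc(C#N)ccc2c(OC)c1Oc1cc(NC(C)C)nc(Nc2ccc(C#N)cc2)n1`) gives > 125000 nM as a limit and not a number. Compound 2 (`CCC(C)Nc1cc(Oc2c(OC)cc3cc(C#N)ccc3c2OC)nc(Nc2ccc(C#N)cc2)n1`) gives > 125000 nM as a limit too. Compound 3 (`COc1cc2cc(C#N)ccc2c(OC)c1Oc1cc(NC2CC2)nc(Nc2ccc(C#N)cc2)n1`) gives > 125000 nM as a limit likewise, and it has no number of its own. Within the data shown here, the whole series so far is summed up as the limit of > 125000 nM in this assay, at which 3 of the 3 values shown sit, and nothing more.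

Compound 4 (`COc1cc2cc(C#N)ccc2c(OC)c1Oc1cc(NCC2CC2)nc(Nc2ccc(C#N)cc2)n1`) carries cyclopropylmethyl in place of cyclopropyl on a nitrogen on an aromatic ring. The measured steps that bear on it are changes on that same nitrogen: a step that the two limits leave unreadable from compound 1 to compound 2 and a step that the two limits leave unreadable from compound 1 to compound 3 and also a step that the two limits leave unreadable from compound 2 to compound 3 as the closest. Among the measured compounds shown here, none of them has a readable size, and none of these side chains brought a number into this assay so far.

What is expected is a number no higher from compound 3 to compound 4 (the limit leaves the size open) in no particular direction and no larger than the scatter. Compound 4 is estimated at 125000 nM with an expected range from 50000 nM to 250000 nM as the likely span.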

Compound 4, half-maximal cytotoxic concentration: > 125000 nM
Compound 4 was reported as a limit; the forecaster's own chance of this, stated with the estimate: 75%; the middle value sits exactly at the limit.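

Compound 4, like compound 1, compound 2 and compound 3, is reported only as a limit and not a number in this assay, so no step among these four compounds can be read. The compounds shown leave open whether these side chains differ at all in cytotoxicity, and the series offers only this: the limit of > 125000 nM in this assay, at which 4 of the 4 values shown sit.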